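Swapping the aryl group on the shared core of compound 3

This account rests on a few compounds, and the source may have more. Where it says the series, first, only, none or still open, it means among the compounds named here.

Compound 3, `CC/C(=C(/c1ccc(/C=C/C(=O)O)cc1)c1cc2ccccc2[nH]1)c1cccc(F)c1C#N`, gives 40 nM in a functional assay on MCF7 cells (Homo sapiens) for inhibition (a higher number here means a weaker inhibitor, a lower number a stronger inhibitor), the second highest of the three numbers shown. Compound 1, `CC/C(=C(/c1ccc(/C=C/C(=O)O)cc1)c1cc2ccccc2[nH]1)c1ccccc1C`, gives 33 nM, and the step of a 1.2-fold higher number from compound 1 to compound 3 (0.08 log units; within the scatter) lies within the scatter. Compound 2, `CC/C(=C(/c1ccc(/C=C/C(=O)O)cc1)c1cc2ccccc2[nH]1)c1cccc(C)c1`, gives 140 nM, and the step of a 3.5-fold lower number from compound 2 to compound 3 (0.54 log units; beyond the scatter) shows that moving from a 3-methylphenyl to a 2-substituted phenyl changed potency modestly; the step of a 4.2-fold higher number from compound 1 to compound 2 (0.63 log units; beyond the scatter) points the same way. Compound 4, `CC/C(=C(/c1ccc(/C=C/C(=O)O)cc1)c1cc2ccccc2[nH]1)c1ccc(C(F)(F)F)cc1Cl`, differs from compound 3 by 2-chloro-4-(trifluoromethyl)phenyl in place of 2-cyano-3-fluorophenyl on a double-bonded chain carbon bound to a double-bonded chain carbon and a saturated chain carbon. Nothing measured here covers a trifluoromethyl group, so the estimate rests on the two 2-substituted phenyls behaving alike. For compound 4 the expected step is a 1.5-fold higher number from compound 3 to compound 4 (0.18 log units; within the scatter), and compound 4 is therefore estimated at 60 nM, within a range of 20 nM to 200 nM.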

Compound 4, half-maximal inhibitory concentration: 27 nM
Beside the measured number, compound 4's estimate is 2.2-fold (0.35 log units) above it, and the stated range covers the measured number.
By their numbers in this assay, from the lowest: compounds 4, 1 and 3 (each within the scatter of the next); then compound 2.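

Here the 2-chloro-4-(trifluoromethyl)phenyl group, larger than the groups before it and with no hydrogen-bond acceptor, fits the pattern of the other 2-substituted phenyls in this assay: neither step (a 1.5-fold lower number from compound 3 to compound 4 (0.17 log units; within the scatter); a 1.2-fold lower number from compound 1 to compound 4 (0.09 log units; within the scatter)) leaves the scatter. Only 3-methylphenyl stands apart, and the gap to it is wider (a 5.2-fold lower number from compound 2 to compound 4 (0.71 log units; beyond the scatter)). No evidence here explains these steps.

The compounds shown leave open whether the 2-chloro group or the trifluoromethyl group matters more, since they change together. On these data alone, a phenyl bearing an amine or a methoxy group at this place also remains untested here.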